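The source may report more compounds than this note shows. Statements on the series, on what has been measured and on what is new or still open speak of the compounds shown alone.

Measured so far:
compound 1, `Cc1cc(=O)oc2cc(OCc3nc(N)nc(Nc4ccc(Cl)cc4)n3)ccc12`: 32500 nM in an assay on COS-7 cells for agonist activity at Free fatty acid receptor 1 (Homo sapiens), read by scintillation counting and inositol phosphate accumulation, with a stated time of 90 min; a higher number here means that more compound is needed for the effect, a lower number that less compound is needed
compound 2, `Cc1cc(=O)oc2cc(OCc3nc(N)nc(Nc4ccc(C(C)C)cc4)n3)ccc12`: 460 nM in this assay

Among the compounds with values here, of these two numbers, compound 2 has the lower; its only neighbour is compound 1, and the step between them, a 71-fold lower number from compound 1 to compound 2 (1.85 log units; beyond the scatter), is large and beyond the scatter. Compound 3, `Cc1cc(=O)oc2cc(OCc3nc(N)nc(Nc4ccc5c(c4)COC5)n3)ccc12`, differs from compound 2 in one place: a group of 9 heavy atoms (8 carbon, 1 oxygen; one five-membered non-aromatic ring with 1 hetero atom, one six-membered aromatic ring of carbon only) in place of a group of 9 heavy atoms (9 carbon; one six-membered aromatic ring of carbon only), on a nitrogen on an aromatic ring. Within the data shown here, the single measured step is the one that bears on this change, since it also alters the group on a nitrogen on an aromatic ring, but it exchanges different groups, so it shows only that this position answers strongly to what sits there, not which way compound 3 will move. The step of a 2.2-fold higher number from compound 2 to compound 3 (0.34 log units; beyond the scatter) is therefore expected to be moderate, towards a higher number, with wide uncertainty. Compound 3 is estimated at 1000 nM, in a range from 200 nM to 5000 nM.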

Compound 3, half-maximal effective concentration: 1330 nM
Estimate against measurement, compound 3: 1.3-fold (0.12 log units) below; the measured number falls inside the stated range.
By their numbers in this assay, from the lowest: compound 2; then compound 3; then compound 1.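

Swapping 4-isopropylphenyl for a group of the same heavy-atom count, with a five-membered non-aromatic ring and 1 hydrogen-bond acceptor, gives a 2.9-fold higher number from compound 2 to compound 3 (0.46 log units; beyond the scatter), so this position distinguishes between two groups of equal size by that count. Set against the chloro-bearing group, the same new group gives a 24-fold lower number from compound 1 to compound 3 (1.39 log units; beyond the scatter), which places compound 3 much closer to compound 2 than to compound 1 and shows that the position accepts more than one group carrying far lower numbers than compound 1. No measurement at hand explains the difference between these groups.

Compound 3 alters both the ring and the oxygen at once, and the compounds shown do not separate the two contributions. As far as these compounds go, how a tert-butyl group, a methoxy group or an amine on this aromatic ring would compare remains open.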